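The compounds below may be only part of what the source reports. "The series", "measured", "known", "first", "only" and "open" are said of these compounds alone.

The series centres on compound 2 `COc1ccccc1-c1csc(N/N=C/c2cc(OC)c(OC)c(Br)c2Br)n1`, which in a functional assay on U-87MG ATCC cells for inhibition, with U-87 MG (Homo sapiens) as the target, read by MTT assay, with a stated time of 48 h (on this read-out lower numbers stand for stronger inhibition and higher numbers for weaker inhibition), gives > 100000 nM, a limit of the assay rather than a number. Compound 1 `COc1cc(/C=N/Nc2nc(-c3ccccc3)cs2)c(Br)c(Br)c1OC`, which carries an unsubstituted phenyl on the shared core, gives 20100 nM in this assay. Compound 3 `COc1ccccc1-c1csc(N/N=C/c2cc(Br)c(OC)c(OC)c2)n1` gives > 100000 nM in this assay, again a limit. Compound 2 therefore stands at the top of what this assay reports, together with compound 3, as the limit of > 100000 nM in this assay, at which 2 of the 3 values shown sit, shows.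

Compound 4 `COc1cc(/C=N/Nc2nc(-c3cccc(Br)c3)cs2)c(Br)c(Br)c1OC` is reached from compound 2 by 3-bromophenyl in place of 2-methoxyphenyl on an aromatic carbon. Within the data shown here, the only readable step that touches the phenyl on the five-membered ring is an at least 4.9-fold higher number from compound 1 to compound 2 (0.69 log units; beyond the scatter), while a step that the two limits leave unreadable from compound 2 to compound 3 gives no size. Compound 4 carries a substituent on that phenyl, as compound 2 does, but a different one, so compound 1 is the nearer reference for the expectation.

Compound 4 is thus expected to move by an at least 2.0-fold lower number from compound 2 to compound 4 (0.30 log units; that floor lies within the scatter), with an estimated value of 50000 nM, in the range from 15000 nM to 150000 nM.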

Compound 4, half-maximal inhibitory concentration: 27600 nM
The estimate for compound 4 lay 1.8-fold (0.26 log units) above the measured number; the measured number falls inside the stated range.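

In this assay, the 3-bromophenyl in place of 2-methoxyphenyl gives an at least 3.6-fold lower number from compound 2 to compound 4 (0.55 log units; beyond the scatter), which shows that a substituent on this phenyl does not by itself carry the number to the limit. The bromo in place of hydrogen gives a 1.4-fold higher number from compound 1 to compound 4 (0.14 log units; within the scatter), so on this read-out compound 4 cannot be told apart from compound 1, whose phenyl is unsubstituted. The size of the step from compound 2 remains a floor, since compound 2 stands at a limit of the assay, not at a number: the limit of > 100000 nM in this assay, at which 2 of the 4 values shown sit.

This change swaps both the substituent and its place on the phenyl, so the compounds shown do not separate the two. They also leave open how a 3-methoxyphenyl, a 2-bromophenyl, or a phenyl bearing an amine or a carboxylic acid would read here.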